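A Methyl Group Added to a Hydroxyphenyl Pyridyl Ketone

The compounds below may be only part of what the source reports. "The series", "measured", "known", "first", "only" and "open" are said of these compounds alone.

Compound 2 `O=C(c1cccnc1)c1ccccc1O` gives 24600 nM in a functional assay on MCF7 cells (Homo sapiens) for cytotoxicity, read by sulforhodamine B assay, with a stated time of 48 h (a higher number here means a weaker inhibitor, a lower number a stronger inhibitor), which is the lower of the two plain numbers seen. Compound 3 `O=C(c1cccnc1)c1cccc(Cl)c1O` gives 26700 nM, and the step of a 1.1-fold higher number from compound 2 to compound 3 (0.04 log units; within the scatter) tells that the two sit side by side. Compound 1 `C=CCOc1cc(Br)ccc1C(=O)c1cccnc1` reaches only a limit of the assay, > 100000 nM, as recorded in the limit of > 100000 nM in this assay, at which 1 of the 3 values shown sits. Compound 4 `Cc1ccc(O)c(C(=O)c2cccnc2)c1` differs from compound 2 by methyl in place of hydrogen on an aromatic carbon. Among the measured compounds shown here, the only measured step that bears on this, a small group added to the phenol ring in compound 3, stayed within the scatter, so the step of a 1.1-fold lower number from compound 2 to compound 4 (0.05 log units; within the scatter) is expected to be no larger than that. Compound 4 is therefore estimated at 22000 nM, with a range from 8000 nM to 60000 nM.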

Compound 4, half-maximal inhibitory concentration: 8040 nM
Compound 4: middle estimate off by 2.7-fold (0.44 log units), on the high side; low and high end bracket the measured number.
By their numbers in this assay, from the lowest: compound 4; then compounds 2 and 3 (each within the scatter of the next). At a limit, above all of these: compound 1.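

Methyl in place of hydrogen, on the aromatic carbon para to the hydroxy group, gives a 3.1-fold lower number from compound 2 to compound 4 (0.49 log units; beyond the scatter) in this assay, a modest change but a real one. The earlier chloro change, a 1.1-fold higher number from compound 2 to compound 3 (0.04 log units; within the scatter), stayed within the scatter, so this is the first single change shown to move the number beyond it. Nothing shown here accounts for why this methyl has that effect.

Going by these compounds, whether an ethyl chain, a methoxy group or an amine at this same place would lower the number further remains open. Also open, on these data alone, is whether this methyl would give a similar step with chloro present too.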